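Stripping the Methylsulfanyl Group from a Nucleoside Core

A few compounds are considered here, and "the series" means these few. Any claim that something is new, unique, unknown or untested is made for them only; others in the source may bear on it.

Compound 2 `CSc1nccc2c1ncn2[C@H]1C[C@H](O)[C@@H](CO)O1` and compound 1 `CN(C)c1nccc2c1ncn2[C@H]1C[C@H](O)[C@@H](CO)O1` share one core and differ at a single aromatic carbon, where compound 2 carries methylsulfanyl in place of the dimethylamino of compound 1. In a functional assay on EL4 cells (Mus musculus) for inhibition, tested at 100 uM (a lower number here means less inhibition, a higher number more inhibition at the concentration tested (going by the name of the read-out)), compound 1 gives < 5%, which is a limit of the assay rather than a number. In this assay compound 2 gives < 5%, again a limit rather than a number. The step that the two limits leave unreadable from compound 1 to compound 2 therefore cannot be sized, since (the limit of < 5% in this assay, at which 2 of the 2 values shown sit).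

Compound 3 `OC[C@H]1O[C@@H](n2cnc3cnccc32)C[C@@H]1O` has not yet been tested in this assay. Its change from compound 2 is hydrogen in place of methylsulfanyl on an aromatic carbon. Going by the values given here, the only measured step, from compound 1 to compound 2, has no readable size, so nothing measured points to a rise or a fall for this kind of change; both measured compounds rest at the limit. With no measured push in either direction, the expected step that the limit leaves unreadable from compound 2 to compound 3 is none beyond the scatter. Compound 3 is therefore estimated to give 3% in this assay, with a range from 0% to 12%, most likely again as a limit.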

Compound 3, a percentage reported as inhibition, at one concentration (the size of the read-out at that concentration, not a potency): < 5%
Compound 3: only a limit was reported; the forecaster's own chance of this, stated with the estimate: 80%; the middle value lies beyond the limit too.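

Compound 3 gives a limit rather than a number, so its steps from compound 2 and from compound 1 cannot be read, and neither swap to hydrogen can be sized: the limit of < 5% in this assay, at which 3 of the 3 values shown sit. The compounds shown leave open whether any group at this aromatic carbon of the shared core can produce measurable inhibition in this assay.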